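From methyl to chloro on the phenyl ring

The compounds below may be only part of what the source reports. "The series", "measured", "known", "first", "only" and "open" are said of these compounds alone.

Values in a functional assay on PC-3 cells (Homo sapiens) for inhibition, read by MTT assay, with a stated time of 48 h (a higher number here means a weaker inhibitor, a lower number a stronger inhibitor), so far:
- compound 1 `Cc1ccc(/C=C2\SC(=O)N(CCNC(=O)Nc3c(C)n(C)n(-c4ccccc4)c3=O)C2=O)cc1` gives 58700 nM
- compound 2 `Cc1c(NC(=O)NCCN2C(=O)S/C(=C\c3ccc([N+](=O)[O-])cc3)C2=O)c(=O)n(-c2ccccc2)n1C` gives 69300 nM
- compound 3 `Cc1ccc(/C=C2\SC(=O)N(CC(=O)Nc3c(C)n(C)n(-c4ccccc4)c3=O)C2=O)cc1` gives 45300 nM

These three values lie within the usual scatter of each other, so compound 3 stands level with compound 1 and compound 2. Compound 4 `Cc1c(NC(=O)CN2C(=O)S/C(=C\c3ccc(Cl)cc3)C2=O)c(=O)n(-c2ccccc2)n1C` differs from compound 3 in one place, with chloro in place of methyl on an aromatic carbon. Among the measured compounds shown here, the one measured step that bears on this swaps a methyl on an aromatic carbon for nitro (a 1.2-fold higher number from compound 1 to compound 2 (0.07 log units; within the scatter)) and stays within the scatter. No step beyond the scatter is therefore expected in this assay for chloro. The estimated change is small (a 1.1-fold higher number from compound 3 to compound 4 (0.03 log units; within the scatter)). Compound 4 is estimated at 48000 nM (expected range 22000 nM to 100000 nM).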

Compound 4, half-maximal inhibitory concentration: 28900 nM
Compound 4: the middle estimate sits 1.7-fold (0.22 log units) above what was measured, and the stated range covers the measured number.
By their numbers in this assay, from the lowest: compounds 4, 3, 1 and 2 (each within the scatter of the next, the first and the last beyond it).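

In this assay, 4-chlorophenyl in place of 4-methylphenyl gives a small step (a 1.6-fold lower number from compound 3 to compound 4 (0.20 log units; within the scatter)). This position, on the ring para to a large group, has now taken both chloro and nitro in place of methyl, each on a different chain, with neither step beyond the scatter. Nothing measured here gives a reason for this result.

As far as these compounds go, whether an amine or a carboxylic acid at this position would give a step beyond the scatter stays open. So does whether chloro gives a similar step on the chain of compound 1.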